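The source may report more compounds than this note shows. Statements on the series, on what has been measured and on what is new or still open speak of the compounds shown alone.

In an in vitro ADME assay on microsomes from liver (Homo sapiens) for metabolic stability, tested at 1 uM (a higher number here means that the compound lasts longer, a lower number that the compound disappears faster), two compounds on a shared core have been measured. Compound 1 `CC(C)[C@]1(C(=O)N2C[C@@H]3C[C@H]2CN3C(=O)OC(C)(C)C)CC[C@@H](NC2CCOCC2)C1` gives > 2 h, which is a limit of the assay and not a number. Compound 2 `CC(C)[C@]1(C(=O)N2C[C@@H]3C[C@H]2CN3C(=O)CC(C)(C)C)CC[C@@H](NC2CCOCC2)C1` gives > 2 h, again only a limit. The record so far therefore reads (the limit of > 2 h in this assay, at which 2 of the 2 values shown sit). Compound 3 `CCC(=O)N1C[C@@H]2C[C@H]1CN2C(=O)[C@@]1(C(C)C)CC[C@@H](NC2CCOCC2)C1` differs from compound 2 as follows: methyl in place of tert-butyl on a saturated chain carbon bound to a carbonyl carbon. Cut one bond further out, this is neopentylcarbonyl to propanoyl. Among the compounds with values here, the only measured step that bears on this change, neopentyl in place of tert-butoxy on a carbonyl carbon, is a step that the two limits leave unreadable from compound 1 to compound 2, so it offers no size to carry over. With neither size nor direction to go on, the expected change is a step that the limit leaves unreadable from compound 2 to compound 3, which is no shift beyond the scatter. Compound 3 is estimated at 3 h, with an expected range from 1.5 h to 6 h.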

Compound 3, half-life: > 2 h
Compound 3: a limit, no number; the forecaster's own chance of this, stated with the estimate: 70%; the middle value is on the limit's open side.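

Compound 3 also gives only a limit of the assay and not a number, so no step among compound 1, compound 2 and compound 3 can be read: the limit of > 2 h in this assay, at which 3 of the 3 values shown sit.

The compounds shown leave open the actual half-life of each in this assay, and whether any of these group changes shifts it at all.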